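The source may report more compounds than this note shows. Statements on the series, on what has been measured and on what is new or still open speak of the compounds shown alone.

The series shares a single core, shown by compound 1 `COC[C@H](NC1CCN(CCCc2c[nH]c3ccc(Cn4cncn4)cc23)CC1)c1ccc(F)cc1`, compound 2 `O[C@H]1Cc2ccccc2C1NC1CCN(CCCc2c[nH]c3ccc(-n4cnnc4)cc23)CC1` and compound 3 `c1ccc(C2CCCCN2C2CCN(CCCc3c[nH]c4ccc(-n5cnnc5)cc34)CC2)cc1`, and all three were measured in an assay on CHO cells for displacement of a labelled ligand from 5-hydroxytryptamine receptor 1B (Homo sapiens); a higher number here means a weaker inhibitor, a lower number a stronger inhibitor. Compound 1 gives 1200 nM in this assay. Compound 2 gives 300 nM, and compound 3 gives 410 nM. Of the three numbers, that of compound 2 is the lowest; compound 3 lies close enough that the two cannot be told apart, while compound 1 sits clearly higher. The unmeasured compound 4 `c1ccc(NCC2CCN(CCCc3c[nH]c4ccc(-n5cnnc5)cc34)CC2)nc1` keeps the core of compound 2 and differs from it in one place: ((pyridin-2-yl)amino)methyl in place of (2-hydroxy-2,3-dihydro-1H-inden-1-yl)amino on a saturated ring carbon. Going by the values given here, no measured pair isolates a change of this kind, so the expectation rests on the spread already seen. The group that enters is smaller than the one that leaves, and compound 4 is expected to move a little toward the higher numbers in this assay, with a step of a 2.0-fold higher number from compound 2 to compound 4 (0.30 log units; within the scatter) of modest size and of uncertain standing against the scatter. Compound 4 is therefore estimated at 600 nM, within a range from 200 nM to 2000 nM.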

Compound 4, half-maximal inhibitory concentration: 3.3 nM
For compound 4 the middle estimate is 180-fold (2.26 log units) above the measured one, outside the stated range (below it).
By their numbers in this assay, from the lowest: compound 4; then compounds 2 and 3 (each within the scatter of the next); then compound 1.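

Going by these compounds alone, the step of a 91-fold lower number from compound 2 to compound 4 (1.96 log units; beyond the scatter) in this assay shows that this saturated ring carbon, three ring bonds from the ring nitrogen, can strongly affect the read-out, which the earlier compounds could not show because none of them formed a single-place pair. It also shows that a large drop in the number does not require the fused ring system, hydroxyl or defined stereocentre of (2-hydroxy-2,3-dihydro-1H-inden-1-yl)amino, since ((pyridin-2-yl)amino)methyl carries none of these. Nothing given here explains the size of the step.

The swap alters the ring, the linking atoms and the hydroxyl together, so the compounds shown do not assign the step to any one of these features. They leave open whether a plain phenyl in place of the pyridin-2-yl ring, or a longer chain between the amine and the saturated ring, would give a similar number.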